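The source may report more compounds than this note shows. Statements on the series, on what has been measured and on what is new or still open speak of the compounds shown alone.

Measured so far:
- compound 1 `O=C(NCCNS(=O)(=O)c1ccc(-c2ccccc2OCc2cccc(O)c2)s1)Nc1cc(Cl)cc(Cl)c1`: > 20000 nM (a limit)
- compound 2 `O=C(NCCNS(=O)(=O)c1ccc(-c2ccccc2Oc2ccc(O)c(O)c2)s1)Nc1cc(Cl)cc(Cl)c1`: 12400 nM
- compound 3 `O=C(NCCNS(=O)(=O)c1ccc(-c2ccccc2O[C@H]2CC[C@H](O)CC2)s1)Nc1cc(Cl)cc(Cl)c1`: > 50000 nM (a limit)

All three were tested in an ADME assay on HEK-293T cells (Homo sapiens) for cytotoxicity, read by CCK-8 assay, with a stated time of 48 h; on this read-out lower numbers stand for stronger inhibition and higher numbers for weaker inhibition. Compound 1 stands at the limit of > 20000 nM in this assay, at which 1 of the 3 values shown sits, so its entry is a limit and not a number. Compound 4 `Cc1cc(C)cc(NC(=O)NCCNS(=O)(=O)c2ccc(-c3ccccc3OCc3cccc(O)c3)s2)c1` keeps the core of compound 1 and changes one group: 3,5-dimethylphenyl in place of 3,5-dichlorophenyl on an amide-type nitrogen.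

The measured steps all change a different place, the group on an oxygen on an aromatic ring. They read: an at least 1.6-fold lower number from compound 1 to compound 2 (0.20 log units; that floor lies within the scatter); an at least 4.0-fold higher number from compound 2 to compound 3 (0.60 log units; beyond the scatter); and a step that the two limits leave unreadable from compound 1 to compound 3. None of them touches the amide-type nitrogen, so they give no direction for this change. Among the measured compounds shown here, they show only that these compounds sit at the high end of this assay. No step beyond the scatter is therefore expected, and compound 4 may also return only a limit. The estimated step is a step that the limit leaves unreadable from compound 1 to compound 4. For compound 4 the expected value is 25000 nM, with an estimated range of 12000 nM to 50000 nM.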

Compound 4, half-maximal inhibitory concentration: > 20000 nM
Compound 4 gave a limit, no number; the forecaster's own chance of this, stated with the estimate: 55%; the middle value is on the limit's open side.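

Compound 1 and compound 4 each gave a limit and not a number, so the step from 3,5-dichlorophenyl to 3,5-dimethylphenyl cannot be read: the limit of > 20000 nM in this assay, at which 2 of the 4 values shown sit. The compounds shown leave open whether this change on the amide-type nitrogen shifts the value at all, and in which direction.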